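Cyclohexyl for (methoxycarbonyl)methyl on a weakly active core

The source may hold more compounds than are shown below. What is called first, only, known or untested is meant among the compounds shown, and "the series" means these compounds.

In a functional assay on DU-145 cells (Homo sapiens) for inhibition, read by trypan blue exclusion, with a stated time of 72 h (a higher number here means a weaker inhibitor, a lower number a stronger inhibitor), compound 1 `COC(=O)Cn1c(=O)c(S(=O)(=O)c2ccc(F)cc2F)cc2cnc(Nc3ccc4[nH]ccc4c3)nc21` gives 10000 nM and belongs to a small set of weak inhibitors. Compound 3 `Cn1c(=O)c(S(=O)(=O)c2ccc(Cl)cc2)cc2cnc(Nc3cnc4ccccc4c3)nc21` gives 15000 nM in the same test, within the usual scatter of compound 1. Compound 2 `Cn1c(=O)c(S(=O)(=O)Cc2ccc(F)cc2)cc2cnc(Nc3ccc4[nH]ccc4c3)nc21` gives 30000 nM as a higher number than compound 1, and that gap lies beyond the scatter. Compound 1 therefore stands level with compound 3 and clearly under compound 2.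

Compound 4 `O=c1c(S(=O)(=O)c2ccc(F)cc2F)cc2cnc(Nc3ccc4[nH]ccc4c3)nc2n1C1CCCCC1` keeps the core of compound 1 and its (2,4-difluorophenyl)sulfonyl group, and it changes one substituent: cyclohexyl in place of (methoxycarbonyl)methyl on an aromatic nitrogen. Within the data shown here, no two measured compounds differ in only one place, and none carries cyclohexyl, so the data hold no direct measure of this change. In this assay an estimated 2.5-fold lower number from compound 1 to compound 4 (0.40 log units; beyond the scatter) is expected as a moderate move toward a lower number and a stronger inhibitor, although the data cannot rule out the opposite direction. Compound 4 is thus estimated at 4000 nM with 800 nM to 15000 nM as the expected range.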

Compound 4, half-maximal inhibitory concentration: 10000 nM
Estimate against measurement, compound 4: 2.5-fold (0.40 log units) below; the measured number falls inside the stated range.
By their numbers in this assay, from the lowest: compounds 1, 4, 3 and 2 (each within the scatter of the next, the first and the last beyond it).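

In this assay, among these compounds, the pair gives the first direct reading at this position on the aromatic nitrogen, and the step runs as no change at the digits printed from compound 1 to compound 4 (within the scatter) with cyclohexyl in place of (methoxycarbonyl)methyl. An open chain ending in an ester is thus exchanged for a six-membered non-aromatic ring of carbon only, and with the (2,4-difluorophenyl)sulfonyl group and the rest of the core held constant, this pair shows no separation beyond the scatter. No supporting data bear on why the two compounds read alike.

Compound 2 and compound 3 each differ from compound 1 and compound 4 in more than one place, so their steps cannot be read, and the pair remains the only direct view of this position. As far as these compounds go, whether a carboxymethyl group, an aminoethyl chain or a phenyl ring on this nitrogen would separate from compound 1 beyond the scatter stays open, as does whether the same exchange would read alike with a different sulfonyl group.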